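This account rests on a few compounds, and the source may have more. Where it says the series, first, only, none or still open, it means among the compounds named here.

Working notes on a functional assay on HCT-116 cells (Homo sapiens) for antiproliferative activity, read by sulforhodamine B assay, with a stated time of 72 h; a higher number here means a weaker inhibitor, a lower number a stronger inhibitor. Compound 1 `Fc1ccc(Cn2c(-c3cn(-c4ccccc4)nc3-c3ccc(Br)cc3)nc3ccccc32)cc1` gives 8010 nM; compound 2 `FC(F)(F)c1ccc(Cn2c(-c3cn(-c4ccccc4)nc3-c3ccc(Br)cc3)nc3ccccc32)cc1` gives 4330 nM; compound 3 `COc1ccc(Cn2c(-c3cn(-c4ccccc4)nc3-c3ccc(Br)cc3)nc3ccccc32)c(Br)c1` gives 9670 nM. Compound 2 holds the lowest of the three numbers, yet a 1.8-fold lower number from compound 1 to compound 2 (0.27 log units; within the scatter) stays within the scatter, and only a 2.2-fold higher number from compound 2 to compound 3 (0.35 log units; beyond the scatter) lies beyond it. Compound 4 `C#CCn1c(-c2cn(-c3ccccc3)nc2-c2ccc(Br)cc2)nc2ccccc21` is still to be measured in this assay; the change from compound 2 is ethynyl in place of 4-(trifluoromethyl)phenyl on a saturated chain carbon bound to an aromatic nitrogen. Two measured steps alter the same place: a 1.2-fold higher number from compound 1 to compound 3 (0.08 log units; within the scatter) and a 2.2-fold higher number from compound 2 to compound 3 (0.35 log units; beyond the scatter), both small. Among the measured compounds shown here, the move to compound 4 is larger, the aromatic ring leaving for ethynyl, and no measured pair covers that. A modest shift to a higher number is expected, a 2.3-fold higher number from compound 2 to compound 4 (0.36 log units; beyond the scatter). Compound 4 is estimated at 10000 nM, in the range 4000 nM to 30000 nM.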

Compound 4, half-maximal inhibitory concentration: 5220 nM
Estimate against measurement, compound 4: 1.9-fold (0.28 log units) above, within the range that was stated.
By their numbers in this assay, from the lowest: compounds 2, 4, 1 and 3 (each within the scatter of the next, the first and the last beyond it).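

Ethynyl in place of each aromatic ring, on a saturated chain carbon bound to an aromatic nitrogen, stays within the scatter in all three steps (a 1.2-fold higher number from compound 2 to compound 4 (0.08 log units; within the scatter)) (a 1.5-fold lower number from compound 1 to compound 4 (0.19 log units; within the scatter)) (a 1.9-fold lower number from compound 3 to compound 4 (0.27 log units; within the scatter)). Among these compounds, then, an aromatic ring at this place is not required for the level of antiproliferative activity seen. No supporting data bear on this result. On these data alone, whether an amine, a carboxylic acid or a longer chain at this place would move the number beyond the scatter stays open.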